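The compounds below may be only part of what the source reports. "The series", "measured", "known", "first", "only" and "open" are said of these compounds alone.

Measured compounds:
- compound 1 `Nc1ccc(Nc2c(C(=O)NCc3ccc(F)cc3)nc(Br)c3cccnc23)cc1`, which in a functional assay on MDA-MB-435 cells (Homo sapiens) for cytotoxicity, read by MTT assay, with a stated time of 72 h (on this read-out higher numbers stand for weaker inhibition and lower numbers for stronger inhibition), gives 7000 nM
- compound 2 `C[C@H](CO)Nc1nc(C(=O)NCc2ccc(F)cc2)c(O)c2ncccc12`, for which this assay reports only the limit > 20000 nM

Among the two entries shown for this assay, compound 1 supplies the only real number. The entry for compound 2 is a limit, not a measured value (the limit of > 20000 nM in this assay, at which 1 of the 2 values shown sits), so compound 2 cannot be placed on the same scale. Within the data shown here, no pair of measured compounds differs in just one place, so the size of any single structural step has not yet been observed here.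

Compound 3 `CNc1c(C(=O)NCc2ccc(F)cc2)nc(Br)c2cccnc12` has not been measured in this assay. It differs from compound 1 in one place: methyl in place of 4-aminophenyl on a nitrogen on an aromatic ring. The group that leaves is a ring carrying a donor and an acceptor; the group that enters is a single carbon with neither. Among the measured compounds shown here, with no measured step to lean on, the expectation rests on the structural change alone. The step of a 2.1-fold higher number from compound 1 to compound 3 (0.33 log units; beyond the scatter) is expected to go toward weaker inhibition, beyond the usual scatter, and there is a fair chance this assay returns only a limit. For compound 3 the estimate is 15000 nM, within 4000 nM to 45000 nM.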

Compound 3, half-maximal inhibitory concentration: > 20000 nM
Compound 3 gave a limit, no number (the forecaster's own chance of this, stated with the estimate: 40%); middle value at least 1.3-fold (0.12 log units) away from the limit.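

The first single-place step seen in this series is the exchange of 4-aminophenyl for methyl: an at least 2.8-fold higher number from compound 1 to compound 3 (0.45 log units; beyond the scatter). Compound 3 gives > 20000 nM in this assay, which is a limit and not a number, so this step has a known minimum but no known full size. The result shows that this position is sensitive to the change, since the compound carrying 4-aminophenyl keeps a measurable value while the one carrying methyl does not, and compound 1 remains the only compound here with a real number on the scale: the limit of > 20000 nM in this assay, at which 2 of the 3 values shown sit.

This single change removes both an aromatic ring and its amino group, so the step cannot say which of the two accounts for the difference, and a plain phenyl on the same nitrogen would separate them. As far as these compounds go, how a longer chain such as ethyl or propyl on that nitrogen would read also stays open, as does the true value of compound 3.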